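Swapping the ester side chain of compound 3 for 2-benzoylethenyl

The source may report more compounds than this note shows. Statements on the series, on what has been measured and on what is new or still open speak of the compounds shown alone.

Of the compounds shown here, three have been read so far in a functional assay on NALM-6 cells (Homo sapiens) for cytotoxicity, with a stated time of 72 h; a higher number here means that more compound is needed for the effect, a lower number that less compound is needed. Compound 1 (`C=C[C@@](C)(/C=C/c1ccc(O)c(/C=C(\C)C(=O)OCC)c1)CCC=C(C)C`) gives > 7500 nM as a limit of the assay, not a number. Compound 2 (`COc1ccc(/C=C/[C@@](C)(/C=C/c2ccc(O)c(/C=C/C#N)c2)CCC=C(C)C)cc1`) gives 16500 nM and is the only one of the three with a number. Compound 3 (`CCOC(=O)/C(C)=C/c1cc(/C=C/[C@](C)(/C=C/c2ccc(OC)cc2)CCC=C(C)C)ccc1O`) stands at > 43400 nM as a limit, so it has no number of its own to start from.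

The step to compound 4 (`COc1ccc(/C=C/[C@@](C)(/C=C/c2ccc(O)c(/C=C/C(=O)c3ccccc3)c2)CCC=C(C)C)cc1`) puts 2-benzoylethenyl in place of 2-(ethoxycarbonyl)prop-1-en-1-yl on an aromatic carbon, ortho to a hydroxy group (2-benzoylethenyl in place of 2-(ethoxycarbonyl)prop-1-en-1-yl on an aromatic carbon). The other end of the molecule stays unchanged.

Within the data shown here, two measured steps touch this. The one at the same aromatic carbon is an at least 2.6-fold higher number from compound 2 to compound 3 (0.42 log units; beyond the scatter) and it brought in the group that compound 4 now loses. The other, a step that the two limits leave unreadable from compound 1 to compound 3 at a different place, gives no usable size. Among the measured compounds shown here, no compound with 2-benzoylethenyl has been measured, so the expectation rests on compound 2 at 16500 nM alone. A lower number is expected in this assay, roughly undoing that single step. The expected change is an at least 2.8-fold lower number from compound 3 to compound 4 (0.46 log units; beyond the scatter) and it is counted from a limit. For compound 4 the estimate is 15000 nM with an expected range of 5000 nM to 45000 nM in this reading.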

Compound 4, half-maximal effective concentration: > 43400 nM
Compound 4: only a limit was reported; the forecaster's own chance of this, stated with the estimate: 25%; at least 2.8-fold (0.46 log units) between middle value and limit.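

In this assay, at this aromatic carbon ortho to a hydroxy group, benzoyl in place of cyano on the ethenyl side chain gives an at least 2.6-fold higher number from compound 2 to compound 4 (0.42 log units; beyond the scatter). A second side chain at this position, 2-benzoylethenyl, now joins 2-(ethoxycarbonyl)prop-1-en-1-yl in giving no number, so the loss seen with the ester is not confined to that group, and 2-cyanoethenyl remains the only side chain here with a measured number. Compound 4 gives a limit and not a number, the same limit as compound 3, so the step between these two cannot be read and sets no order between the two side chains: the limit of > 43400 nM in this assay, at which 2 of the 4 values shown sit.

From the compounds shown here alone, it remains open whether any side chain at this carbon gives a lower number than compound 2, which gives 16500 nM. A carboxylic acid or an aminomethyl group in place of the cyano would test whether the nitrile itself matters or whether the benzoyl and the ester simply fall outside what this position accepts.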